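Swapping Fluoro for Piperidinyl in an Aryl Thiourea Series

This account rests on a few compounds, and the source may have more. Where it says the series, first, only, none or still open, it means among the compounds named here.

Measured so far:
Compound 1, `CNC(=S)Nc1cccc(OCCCCCc2ccccc2)c1`, in an ADME assay on Ava5 cells (Homo sapiens) for cytotoxicity; a higher number here means that more compound is tolerated, a lower number that less compound is tolerated: > 50000 nM, which is a limit of the assay and not a number.
Compound 2, `NC(=S)Nc1cccc(OCCCCCOc2ccc(F)cc2)c1`, in this assay: 5000 nM.
Compound 3, `NC(=S)Nc1cccc(OCCCCCOc2cccc(-c3ccccc3)c2)c1`, in this assay: 13000 nM.

Compound 2 holds the lowest of the two numbers in this assay; compound 3 gives a higher number, and the gap between them lies beyond the scatter. Compound 1 is read only as the limit of > 50000 nM in this assay, at which 1 of the 3 values shown sits, so it offers no number to compare against.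

Compound 4, `NC(=S)Nc1cccc(OCCCCCOc2ccc(N3CCCCC3)cc2)c1`, shares the core of compound 2 and differs from it in one place: piperidin-1-yl in place of fluoro on an aromatic carbon. Among the compounds with values here, no step between two measured compounds shows what this kind of swap does in this assay, so the expectation rests on the numbers of compound 2 and compound 3 alone. The step expected in this assay is a 1.6-fold higher number from compound 2 to compound 4 (0.20 log units; within the scatter), a modest rise with wide uncertainty. Compound 4 is therefore estimated at 8000 nM, with a plausible range from 2500 nM to 30000 nM.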

Compound 4, half-maximal cytotoxic concentration: 12000 nM
For compound 4 the middle estimate is 1.5-fold (0.18 log units) below the measured one, and the stated range covers the measured number.
By their numbers in this assay, from the lowest: compound 2; then compounds 4 and 3 (each within the scatter of the next). At a limit, above all of these: compound 1.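

Piperidin-1-yl in place of fluoro, on an aromatic carbon para to a large group, gives in this assay a 2.4-fold higher number from compound 2 to compound 4 (0.38 log units; beyond the scatter) and is the first change in this series that can be read in one place. Six heavy atoms and a six-membered non-aromatic ring enter where a single fluorine stood, and the number goes up rather than down, so this position accepts a much larger group without less compound being tolerated. Compound 1 remains a limit and not a number, so it adds no measured value to this reading: the limit of > 50000 nM in this assay, at which 1 of the 4 values shown sits.

The compounds shown leave open whether the rise follows the ring as a whole or its nitrogen, and how a morpholin-4-yl, a dimethylamino or a cyclohexyl group would read at the same position. They also leave open whether the same swap would give a step of similar size on a longer chain or with a methyl group on the thiourea nitrogen, since this single step rests on one pair of compounds.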